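Fitting a 6-methoxy-1,3-benzothiazol-2-yl group onto the chain

This account rests on a few compounds, and the source may have more. Where it says the series, first, only, none or still open, it means among the compounds named here.

Compound 1 `CC(C)(C)Sc1c(CC(C)(C)C(=O)O)n(Cc2ccc(Cl)cc2)c2ccc(OCc3ccc4cc(F)ccc4n3)cc12` gives 880 nM
Compound 2 `CC(C)(C)Sc1c(CC(C)(C)C(=O)O)n(Cc2ccc(Cl)cc2)c2ccc(OCc3ccc4cccnc4n3)cc12` gives > 3000 nM (a limit of the assay, not a number)
Compound 3 `CC(C)(C)Sc1c(CC(C)(C)C(=O)O)n(Cc2ccc(Cl)cc2)c2ccc(OCc3ccc4cnccc4n3)cc12` gives 980 nM

In a functional assay (blood) for inhibition, with Homo sapiens as the target (on this read-out higher numbers stand for weaker inhibition and lower numbers for stronger inhibition), compound 3 gives 980 nM and sits with compound 1, the step of a 1.1-fold higher number from compound 1 to compound 3 (0.05 log units; within the scatter) being no real change. Compound 4 `COc1ccc2nc(COc3ccc4c(c3)c(SC(C)(C)C)c(CC(C)(C)C(=O)O)n4Cc3ccc(Cl)cc3)sc2c1` alters the same place, and a group of 11 heavy atoms (8 carbon, 1 nitrogen, 1 oxygen, 1 sulfur; one five-membered aromatic ring with 2 hetero atoms, one six-membered aromatic ring of carbon only) in place of a group of 10 heavy atoms (8 carbon, 2 nitrogen; 2 six-membered aromatic rings with 1 hetero atom each), on a saturated chain carbon bound to an oxygen on an aromatic ring describes the change. Among the measured compounds shown here, three measured steps bear on it. Exchanging groups here gave a 1.1-fold higher number from compound 1 to compound 3 (0.05 log units; within the scatter) in one case, yet an at least 3.4-fold higher number from compound 1 to compound 2 (0.53 log units; beyond the scatter) in another and an at least 3.0-fold lower number from compound 2 to compound 3 (0.48 log units; beyond the scatter) in a third, so the outcome depends on the group. For the measured compounds named here, no measured compound carries the new group, so the two compounds that gave numbers serve as the guide. The estimated change is a 1.2-fold higher number from compound 3 to compound 4 (0.09 log units; within the scatter) and no step beyond the scatter is expected. For compound 4 the expected value is 1200 nM with an estimated range of 400 nM to 3500 nM in this assay overall.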

Compound 4, half-maximal inhibitory concentration: 670 nM
Compound 4: middle estimate off by 1.8-fold (0.25 log units), on the high side; measured number inside the range.
By their numbers in this assay, from the lowest: compounds 4, 1 and 3 (each within the scatter of the next). At a limit, above all of these: compound 2.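

In this assay the 6-methoxy-1,3-benzothiazol-2-yl group holds the level of the earlier groups, with a 1.5-fold lower number from compound 3 to compound 4 (0.17 log units; within the scatter) and a 1.3-fold lower number from compound 1 to compound 4 (0.12 log units; within the scatter) both staying within the scatter. Among the compounds shown here, a five-membered aromatic ring with 2 hetero atoms is therefore accepted on this chain carbon, and the one new step beyond the scatter is an at least 4.4-fold lower number from compound 2 to compound 4 (0.65 log units; beyond the scatter) and not a gain over compound 1 or compound 3. That step rests on a limit of the assay for compound 2, not on a number: the limit of > 3000 nM in this assay, at which 1 of the 4 values shown sits.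

The compounds shown cannot separate the part played by the methoxy group from that of the 1,3-benzothiazol-2-yl ring system. Going by these compounds, whether an amine or a longer alkoxy chain in place of the methoxy would hold this level also stays open.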